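Hydroxyalkyl triazole series: carbamate removal at the chain

A few compounds are considered here, and "the series" means these few. Any claim that something is new, unique, unknown or untested is made for them only; others in the source may bear on it.

Measured so far:
compound 1 `OC1CCCCC1n1cc(CN2CCN(c3ccccc3)CC2)nn1` gives 47% in an assay on nucleic acid for inhibition of Nucleic Acid, read by fluorescence, tested at 100 uM; a lower number here means less inhibition, a higher number more inhibition at the concentration tested (going by the name of the read-out)
compound 2 `OC(COCc1ccccc1)Cn1cc(CN2CCN(c3ccccc3)CC2)nn1` gives 37%
compound 3 `CCCCNC(=O)OCC(O)Cn1cc(CN2CCN(c3ccccc3)CC2)nn1` gives 11%

Compound 3 stands lowest of the three numbers. Its nearest neighbour is compound 2, and the step of a number 26 percentage points lower from compound 2 to compound 3 (beyond the scatter) is beyond the scatter; compound 1 lies further off still, also beyond the scatter.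

Compound 4 `CCCCC(O)Cn1cc(CN2CCN(c3ccccc3)CC2)nn1` has not been measured. The change from compound 3 is propyl in place of (butylcarbamoyl)oxy on a saturated chain carbon, two bonds along the chain from an oxygen on a saturated carbon. Among the compounds with values here, no measured step follows this exact change. Within the data shown here, the only step known, butylcarbamoyl in place of benzyl on an oxygen on a saturated carbon, is a number 26 percentage points lower from compound 2 to compound 3 (beyond the scatter), and it touches the same part of the molecule, the oxygen on the saturated carbon that now departs altogether. Among the measured compounds shown here, since the butylcarbamoyl group accompanied the lowest number, its removal is expected to move the number back toward the range of compounds 1 and 2 rather than lower, though a plain propyl chain has no precedent here, so the expected step of a number 19 percentage points higher from compound 3 to compound 4 (beyond the scatter) carries a wide uncertainty. Compound 4 is estimated at 30%, with a range from 10% to 55%.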

Compound 4, a percentage reported as inhibition, at one concentration (the size of the read-out at that concentration, not a potency): 47%
Estimate against measurement, compound 4: 17 percentage points below; measured number inside the range.
By their numbers in this assay, from the lowest: compound 3; then compounds 2, 1 and 4 (each within the scatter of the next).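

In this assay, propyl in place of (butylcarbamoyl)oxy on this saturated chain carbon gives a number 36 percentage points higher from compound 3 to compound 4 (beyond the scatter) and so ties the low number of compound 3 to the (butylcarbamoyl)oxy group, not to the hydroxyalkyl chain shared by both compounds. Propyl and benzyloxy at this place cannot be told apart, with a number 10 percentage points higher from compound 2 to compound 4 (within the scatter) on record, and the open 2-hydroxyhexyl group on the aromatic nitrogen cannot be told apart from 2-hydroxycyclohexyl, with no change at the digits printed from compound 1 to compound 4 (within the scatter) on record. Nothing measured on these compounds accounts for these steps.

Still open, as far as these compounds go, is whether a longer chain, an amine or a carboxylic acid at this place would shift the number. Also open, from the compounds shown here alone, is whether an amide or a urea at this place would give a number as low as that of compound 3.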